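Lengthening the alkyl chain on the core of compound 3

The compounds below may be only part of what the source reports. "The series", "measured", "known", "first", "only" and "open" are said of these compounds alone.

Compound 3 `CCCc1nc(C(F)(F)F)ccc1CNC(=O)C(C)c1ccc(NS(C)(=O)=O)c(F)c1` gives 22.7 nM in an assay on CHO cells for antagonist activity at transient receptor potential cation channel subfamily V member 1 (Homo sapiens), read by FLIPR and calcium flux (on this read-out lower numbers stand for stronger inhibition and higher numbers for weaker inhibition), the lowest of the three numbers measured; compound 1 `CC(C(=O)NCc1ccc(C(F)(F)F)nc1Br)c1ccc(NS(C)(=O)=O)c(F)c1` gives 169 nM and compound 2 `Cc1nc(C(F)(F)F)ccc1CNC(=O)C(C)c1ccc(NS(C)(=O)=O)c(F)c1` gives 387 nM. Compound 4 `CCCCCc1nc(C(F)(F)F)ccc1CNC(=O)C(C)c1ccc(NS(C)(=O)=O)c(F)c1` differs from compound 3 by ethyl in place of hydrogen on a saturated chain carbon, three bonds along the chain from an aromatic carbon. The step that bears most directly on this is a 17-fold lower number from compound 2 to compound 3 (1.23 log units; beyond the scatter), a large gain from growing the same chain; a 7.4-fold lower number from compound 1 to compound 3 (0.87 log units; beyond the scatter) points the same way. Whether a still longer chain keeps helping is not shown by these three compounds, so for compound 4 only a small step toward a lower number, if any beyond the scatter, is expected: a 1.3-fold lower number from compound 3 to compound 4 (0.10 log units; within the scatter). Compound 4 is therefore estimated at 18 nM, with a range from 5 nM to 70 nM.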

Compound 4, inhibition constant: 1 nM
The estimate for compound 4 lay 18-fold (1.26 log units) above the measured number; measured number below the stated range.
By their numbers in this assay, from the lowest: compound 4; then compound 3; then compound 1; then compound 2.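

In this assay, going from propyl to pentyl gives a 23-fold lower number from compound 3 to compound 4 (1.36 log units; beyond the scatter) and so shows that the gain from lengthening this chain did not stop at propyl. Among these compounds, the full span at this position is wider than the earlier compounds showed, with a 390-fold lower number from compound 2 to compound 4 (2.59 log units; beyond the scatter) from the methyl group and a 170-fold lower number from compound 1 to compound 4 (2.23 log units; beyond the scatter) from the bromo group. Nothing available here explains why pentyl does so well. Still open, as far as these compounds go, is whether a longer chain such as heptyl would lower the number further or reverse the trend. From the compounds shown here alone, a branched chain or a cyclohexyl ring in this place is equally open.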